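The source may report more compounds than this note shows. Statements on the series, on what has been measured and on what is new or still open speak of the compounds shown alone.

Measured compounds and their values:

Compound 1, `O=C1NNC(=O)C2(CSC3=C2C(=O)c2ncccc2C3=O)N1`, gives 5000 nM in a functional assay on XF498 cells (Homo sapiens) for antiproliferative activity, read by MTT assay, with a stated time of 96 h; a higher number here means a weaker inhibitor, a lower number a stronger inhibitor.
Compound 2, `O=C1C2=C(C(=O)c3ncccc31)C1(CS2)NC(=O)N(c2ccc([N+](=O)[O-])cc2)C1=O`, gives 1030 nM in this assay.
Compound 3, `Cc1ccc(N2NC(=O)NC3(CSC4=C3C(=O)c3ncccc3C4=O)C2=O)cc1`, gives 3800 nM in this assay.

Compound 2 stands at the lowest of the three numbers, and its distance from both compound 3 and compound 1 lies beyond the scatter. Compound 4, `CCCCCc1ccc(N2C(=O)NC3(CSC4=C3C(=O)c3ncccc3C4=O)C2=O)cc1`, differs from compound 2 in one place: pentyl in place of nitro on an aromatic carbon. Among the compounds with values here, only one step between measured compounds is known, a 1.3-fold lower number from compound 1 to compound 3 (0.12 log units; within the scatter), and it concerns a different place on the shared core, the amide-type nitrogen in the ring, so it does not bear on an exchange on the aromatic carbon. Within the data shown here, no measured pair shows a nitro against a pentyl. What can be said is that, where compound 2 carries the nitro-bearing ring, a 4-methylphenyl is carried instead by compound 3, which sits at the higher number 3800 nM. The step of a 2.4-fold higher number from compound 2 to compound 4 (0.39 log units; beyond the scatter) is therefore expected to run toward a higher number, though with wide uncertainty. Compound 4 is estimated at 2500 nM, within 800 nM to 8000 nM.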

Compound 4, half-maximal inhibitory concentration: 830 nM
The estimate for compound 4 lay 3.0-fold (0.48 log units) above the measured number, within the range that was stated.
By their numbers in this assay, from the lowest: compounds 4 and 2 (each within the scatter of the next); then compounds 3 and 1 (each within the scatter of the next).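

In this assay, putting pentyl in place of nitro on the aromatic carbon gives a 1.2-fold lower number from compound 2 to compound 4 (0.09 log units; within the scatter), the first step read at this position. In this one pair, a group holding nitrogen and oxygen and an all-carbon chain with no hydrogen-bond acceptors therefore cannot be told apart by this read-out, so the difference between them at this place leaves no mark on the number. Nothing available explains why the two groups read alike.

On these data alone, whether an amine or a carboxylic acid on this carbon, or a chain longer than pentyl, would keep the number in the same range stays open. Compound 3 differs from compound 2 and compound 4 in more than one place, so it cannot show what a methyl would do here.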